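Swapping Chloro for Bromo on Two Related Amides

The source may report more compounds than this note shows. Statements on the series, on what has been measured and on what is new or still open speak of the compounds shown alone.

Compound 1, `CO/C(=C\c1ccc(Cl)cc1)C(=O)Nc1ccc(C)cc1`: in a functional assay on cells (Splenocyte, Mus musculus, strain BALB/c) for inhibition, read by MTT assay, with a stated time of 48 h (a higher number here means a weaker inhibitor, a lower number a stronger inhibitor), compound 1 gives 12700 nM.
Compound 2, `CO/C(=C\c1ccc(Br)cc1)C(=O)Nc1ccc(C)cc1`: in this assay compound 2 gives 12900 nM.
Compound 3, `CO/C(=C\c1ccc(OC)cc1)C(=O)Nc1ccc(Cl)cc1`: in this assay compound 3 gives 14700 nM.

Compound 1 and compound 2 share one core, while compound 3 is built on another; the difference between the two cores is not broken down here. From compound 1 to compound 2 the change is bromo in place of chloro on an aromatic carbon and it produced a 1.0-fold higher number from compound 1 to compound 2 (0.01 log units; within the scatter). Compound 4, `CO/C(=C\c1ccc(OC)cc1)C(=O)Nc1ccc(Br)cc1`, is not yet measured. It arises from compound 3 by bromo in place of chloro on an aromatic carbon, the same change at the same place on a different core. Because a 1.0-fold higher number from compound 1 to compound 2 (0.01 log units; within the scatter) lay within the scatter, the step from compound 3 to compound 4 is expected to be a 1.0-fold higher number from compound 3 to compound 4 (0.01 log units; within the scatter). Compound 4 is therefore estimated at 15000 nM in this assay, most likely between 7500 nM and 30000 nM.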

Compound 4, half-maximal inhibitory concentration: 1770 nM
Estimate against measurement, compound 4: 8.5-fold (0.93 log units) above; the whole stated range lies above it.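

On the core of compound 3, bromo in place of chloro gave an 8.3-fold lower number from compound 3 to compound 4 (0.92 log units; beyond the scatter) in this assay, so compound 4 is the stronger inhibitor of that pair. The same swap therefore did not carry over from one core to the other with the same size of effect: the same change on two cores in this assay, a 1.0-fold higher number (0.01 log units; within the scatter) from compound 1 to compound 2 and an 8.3-fold lower number (0.92 log units; beyond the scatter) from compound 3 to compound 4, 8.4-fold (0.93 log units) apart, beyond the scatter of two such steps. This shows that, in these two pairs, the result of the swap depends on the core, but it does not show which part of the core is responsible or why.

The compounds shown leave open how the swap would behave on a third core. They also leave open whether a fluoro or iodo group in that place would give a number like that of bromo or like that of chloro.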